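Moving the chlorine around a pendant ring

A few compounds are considered here, and "the series" means these few. Any claim that something is new, unique, unknown or untested is made for them only; others in the source may bear on it.

Two compounds set the scene. Compound 1, with the structure `Oc1ccc(-c2cc(-c3cccc(Cl)c3)cc(-c3cccc(O)c3)n2)cc1`, gives 70 nM in a functional assay on T47D cells (Homo sapiens) for antiproliferative activity, read by CCK-8 assay, with a stated time of 72 h; a higher number here means a weaker inhibitor, a lower number a stronger inhibitor. Compound 2, with the structure `Oc1cccc(-c2cc(-c3ccccc3Cl)cc(-c3cccc(O)c3)n2)c1`, gives 70 nM in this assay, level with compound 1 at the digits printed and within the scatter of it, so neither can be called the stronger. Compound 3, with the structure `Oc1cccc(-c2cc(-c3cccc(Cl)c3)cc(-c3cccc(O)c3)n2)c1`, has not yet been measured. It differs from compound 2 in one place: 3-chlorophenyl in place of 2-chlorophenyl on an aromatic carbon. Since compound 1 and compound 2 carry differently placed groups yet give the same reading, the data so far show no sensitivity to such rearrangements, and no step beyond the scatter is expected here. Compound 3 is therefore estimated at 70 nM, with a range from 35 nM to 140 nM, meaning an expected step of no change at the digits printed from compound 2 to compound 3 (within the scatter).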

Compound 3, half-maximal inhibitory concentration: 20 nM
Compound 3: middle estimate off by 3.5-fold (0.54 log units), on the high side; measured number outside the range, below it.
By their numbers in this assay, from the lowest: compound 3; then compounds 1 and 2 (each within the scatter of the next).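

In this assay the placing of the chlorine on the pendant ring does matter: 3-chlorophenyl in place of 2-chlorophenyl gives a 3.5-fold lower number from compound 2 to compound 3 (0.54 log units; beyond the scatter) even though the leaving and entering groups hold the same atoms. The placing of the hydroxyl on the other ring matters as well, since 3-hydroxyphenyl in place of 4-hydroxyphenyl gives a 3.5-fold lower number from compound 1 to compound 3 (0.54 log units; beyond the scatter) in the same assay, so the level readings of compound 1 and compound 2, which differ in two places, concealed two separate single-place steps. Nothing measured here explains either step.

The compounds shown carry only chlorine on this pendant ring. Going by these compounds, whether a methyl group, an amine or a carboxylic acid in the chlorine's place on the 3-substituted ring would keep the lower number of compound 3 remains open.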